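From compound 3 to compound 4: an aryl exchange

A few compounds are considered here, and "the series" means these few. Any claim that something is new, unique, unknown or untested is made for them only; others in the source may bear on it.

Measured so far in a functional assay on A549 cells (Homo sapiens) for cytotoxicity, read by MTT assay, with a stated time of 72 h; a higher number here means a weaker inhibitor, a lower number a stronger inhibitor:
Compound 1 `Cn1ccc2c(Oc3ccc(NC(=O)c4cc5cccnc5n(-c5ccc(C(F)(F)F)cc5Cl)c4=O)cc3F)ncnc21` gives "not active" (no number reported)
Compound 2 `O=C(Nc1ccc(Oc2ncnc3[nH]ccc23)c(F)c1)c1cc2cccnc2n(-c2ccccc2)c1=O` gives 45500 nM
Compound 3 `O=C(Nc1ccc(Oc2ncnc3[nH]ccc23)c(F)c1)c1cc2cccnc2n(-c2ccc(Br)cc2)c1=O` gives 27300 nM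

For the measured compounds named here, compound 3 stands level with the only other number in the set. The gap is a 1.7-fold lower number from compound 2 to compound 3 (0.22 log units; within the scatter) and no order is read from it. The next entry is compound 4 `O=C(Nc1ccc(Oc2ncnc3[nH]ccc23)c(F)c1)c1cc2cccnc2n(-c2ccc(C(F)(F)F)cc2Cl)c1=O` and the change leading to it is 2-chloro-4-(trifluoromethyl)phenyl in place of 4-bromophenyl on an aromatic nitrogen on an aromatic nitrogen of a six-membered aromatic ring with 1 nitrogen.

Going by the values given here, the step already measured is the only one bearing on this change: it also alters the group on that nitrogen, and it stays within the scatter. Among the compounds with values here, compound 1 carries the same 2-chloro-4-(trifluoromethyl)phenyl group but offers no number, and no step from it can be sized. A result without a number therefore remains possible for compound 4. If a number is returned, no step beyond the scatter is expected in this assay and no direction is favoured. The estimate amounts to a 1.1-fold lower number from compound 3 to compound 4 (0.04 log units; within the scatter) as an expected step. Compound 4 is estimated at 25000 nM with an expected range of 8000 nM to 60000 nM in this series.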

Compound 4, half-maximal inhibitory concentration: 283000 nM
The estimate for compound 4 lay 11-fold (1.05 log units) below the measured number, outside the stated range (above it).
By their numbers in this assay, from the lowest: compounds 3 and 2 (each within the scatter of the next); then compound 4.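

In this assay, the group on the aromatic nitrogen can move the number beyond the scatter: the change to 2-chloro-4-(trifluoromethyl)phenyl gives a 10-fold higher number from compound 3 to compound 4 (1.02 log units; beyond the scatter) and a 6.2-fold higher number from compound 2 to compound 4 (0.79 log units; beyond the scatter), whereas the earlier exchange of hydrogen for bromo gave only a 1.7-fold lower number from compound 2 to compound 3 (0.22 log units; within the scatter). Both new steps point the same way, which makes compound 4 the weakest of the three compounds with numbers, and this position is therefore not indifferent to the aryl group it carries. No measurement available here bears on the reason for this loss.

Which part of the entering group carries the step stays open, since the chloro and the trifluoromethyl enter together in compound 4 and only a 2-chlorophenyl or a 4-(trifluoromethyl)phenyl on the same nitrogen would separate them. Also open is how this position responds to a group of a different kind, such as an amine or a carboxylic acid on the phenyl ring, as all the groups shown there are hydrogen, halogen or trifluoromethyl.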